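The compounds below may be only part of what the source reports. "The series", "measured", "known", "first", "only" and "open" are said of these compounds alone.

Compound 1 `CO[C@@H]1[C@H]2OC(=O)C[C@H]2O[C@@H]1[C@@H](O)c1ccccc1`: 35200 nM
Compound 2 `CO[C@@H]1[C@H]2OC(=O)C[C@H]2O[C@@H]1C(O)(c1ccccc1)c1ccccc1`: 51000 nM
Compound 3 `CO[C@@H]1[C@H]2OC(=O)C[C@H]2O[C@@H]1[C@H](O)c1ccccc1`: 28600 nM

These values were measured in a functional assay on MDA-MB-231 cells (Homo sapiens) for inhibition, read by MTT assay, with a stated time of 72 h; a higher number here means a weaker inhibitor, a lower number a stronger inhibitor. In this assay compound 1 gives 35200 nM, and neither of the other two compounds stands apart from it beyond the usual scatter of repeated measurements. Its nearest neighbour is compound 3 and its furthest is compound 2, so compound 1 offers no clear ranking to build on.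

The next compound is compound 4 `CO[C@@H]1[C@H]2OC(=O)C[C@H]2O[C@@H]1[C@@H](OC)c1ccccc1`. It keeps the core of compound 1 and changes one thing, hydroxy to methoxy: methyl in place of hydrogen on an oxygen on a saturated carbon. In words, a methyl takes the place of hydrogen on an oxygen on a saturated carbon.

Going by the values given here, only one measured step is available as a guide: a 1.2-fold lower number from compound 1 to compound 3 (0.09 log units; within the scatter). From the compounds shown here alone, that step reflects (the fact that compounds 1 and 3 differ only in the configuration as drawn), so the hydroxy stays in place and the swap now in question remains untested. The data therefore give no reason to predict a shift in either direction, though they cannot rule one out, and the range must stay wide.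

The expected result is no change beyond the scatter, with an estimated 1.1-fold lower number from compound 1 to compound 4 (0.04 log units; within the scatter).

For compound 4 the expected value is 32000 nM, with an estimated range of 12000 nM to 75000 nM.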

Compound 4, half-maximal inhibitory concentration: 2650 nM
The estimate for compound 4 lay 12-fold (1.08 log units) above the measured number, outside the stated range (below it).
By their numbers in this assay, from the lowest: compound 4; then compounds 3, 1 and 2 (each within the scatter of the next).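

In this assay, putting a methyl in place of hydrogen on the oxygen on this saturated carbon gives a 13-fold lower number from compound 1 to compound 4 (1.12 log units; beyond the scatter) and so moves the number far more than any earlier comparison did. Going by these compounds alone, this position therefore responds to a small change: hydroxy to methoxy adds a single carbon, yet it produces the only step in this set that lies beyond the scatter. The earlier step could not reveal this, since the hydroxy stayed in place and only its orientation as drawn changed: the fact that compounds 1 and 3 differ only in the configuration as drawn.

The compounds shown leave open whether the loss of the hydrogen or the arrival of the methyl matters more, and they give no reason for the drop in the number. They also leave open whether an ethyl on this oxygen or an amine in place of the methoxy would lower the number further, and whether the same methyl would have a similar effect on compound 3, which carries the other drawn configuration at this carbon.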